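The source may report more compounds than this note shows. Statements on the series, on what has been measured and on what is new or still open speak of the compounds shown alone.

Three compounds share one core and differ only in the group that sits on the saturated chain carbon bound to an aromatic nitrogen. Compound 1 `O=c1ccoc2cc(OCc3cn(Cc4ccccc4)nn3)ccc12` carries a plain phenyl there, and in a functional assay on MDA-MB-231 cells (Homo sapiens) for cytotoxicity, read by MTT assay, with a stated time of 48 h (on this read-out lower numbers stand for stronger inhibition and higher numbers for weaker inhibition), compound 1 reaches only the limit of the measurement, > 100000 nM. Compound 2 `O=c1ccoc2cc(OCc3cn(Cc4cccc([N+](=O)[O-])c4)nn3)ccc12` carries a 3-nitrophenyl, and in this assay compound 2 likewise stops at the limit, > 100000 nM. Compound 3 `O=c1ccoc2cc(OCc3cn(Cc4ccccc4F)nn3)ccc12` carries a 2-fluorophenyl, and in this assay compound 3 gives 29800 nM. Among the compounds with values here, that is the only number among the three, the rest being (the limit of > 100000 nM in this assay, at which 2 of the 3 values shown sit). Within the data shown here, the step of an at least 3.3-fold lower number from compound 1 to compound 3 (0.52 log units; beyond the scatter) and the step of an at least 3.3-fold lower number from compound 2 to compound 3 (0.52 log units; beyond the scatter) are both at least modest and both run toward compound 3, which therefore stands as the one compound with a readable value.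

Compound 4 `N#Cc1ccc(Cn2cc(COc3ccc4c(=O)ccoc4c3)nn2)cc1` has not yet been measured. It differs from compound 3 by 4-cyanophenyl in place of 2-fluorophenyl on a saturated chain carbon bound to an aromatic nitrogen. The fluorine that set compound 3 apart from compound 1 is gone, and the ring instead carries a nitrile, where compound 2 carried a nitro and reached no number. With two of three measured compounds at the limit and the one substituent that produced a number removed, the expected step is a 2.7-fold higher number from compound 3 to compound 4 (0.43 log units; beyond the scatter), toward weaker inhibition. Compound 4 is therefore estimated at 80000 nM in this assay, within a range from 25000 nM to 200000 nM, and a limit rather than a number is a real possibility.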

Compound 4, half-maximal inhibitory concentration: > 100000 nM
Compound 4: only a limit was reported; the forecaster's own chance of this, stated with the estimate: 55%; at least 1.2-fold (0.09 log units) between middle value and limit.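

Putting 4-cyanophenyl in place of 2-fluorophenyl on the saturated chain carbon bound to an aromatic nitrogen gives an at least 3.3-fold higher number from compound 3 to compound 4 (0.52 log units; beyond the scatter), so the readable value of compound 3 does not survive this change, just as compound 2 with its 3-nitrophenyl gave no number. The steps from compound 1 and from compound 2 to compound 4 cannot be read, since both ends of each are limits, and these three compounds therefore cannot be put in order. At this position a nitrile joins the nitro and the unsubstituted phenyl among the groups without a number, compound 3 being the one exception, and the set now stands as follows: the limit of > 100000 nM in this assay, at which 3 of the 4 values shown sit.

From the compounds shown here alone, whether a chloro, a methoxy or an amine in place of the fluorine of compound 3 would also give a readable value in this assay remains open. Also open, going by these compounds, is how compound 1, compound 2 and compound 4 would compare if their values could be read past the limit.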